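Imidazoline to methylimidazole on a tetralin sulfonamide core

This account rests on a few compounds, and the source may have more. Where it says the series, first, only, none or still open, it means among the compounds named here.

Working notes on a small set of compounds tested in a functional assay on Urethra with Alpha-1A adrenergic receptor (Oryctolagus cuniculus) as the target; on this read-out lower numbers stand for smaller maximal responses and higher numbers for larger maximal responses. Among the measured compounds shown here, compound 1 `CS(=O)(=O)Nc1cccc2c1CCCC2C1=NCCN1` is the only member with a single number in this assay, where compound 1 gives 87%, and so it is the reference point for the step to follow. Compound 2 `CS(=O)(=O)Nc1cccc2c1CCC=C2c1c[nH]cn1` carries an imidazole on an unsaturated core and gives repeated values that scatter widely, 57%; 23% (2 entries), as recorded in the several entries of compound 2 in this assay, 57%; 23% (2 entries). Compound 3 `Cn1cnc(C2CCCc3c(NS(C)(=O)=O)cccc32)c1` is not yet measured. It differs from compound 1 by a group of 6 heavy atoms (4 carbon, 2 nitrogen; one five-membered aromatic ring with 2 hetero atoms) in place of a group of 5 heavy atoms (3 carbon, 2 nitrogen; one five-membered non-aromatic ring with 2 hetero atoms), on a saturated ring carbon. The two values of compound 2 sit well under that of compound 1, and the change from compound 1 to compound 3 likewise removes the only hydrogen-bond donor of the entering and leaving groups, so a step down beyond the scatter is expected, a number 45 percentage points lower from compound 1 to compound 3 (beyond the scatter). For compound 3 the efficacy is estimated at 42%, within a range of 15% to 72%.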

Compound 3, largest response reached (reported as efficacy), in percent of the reference or control that the assay uses: 40%
The estimate for compound 3 lay 2 percentage points above the measured number, within the range that was stated.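

In this assay, putting 1-methyl-1H-imidazol-4-yl on the saturated ring carbon in place of the five-membered non-aromatic ring gives a number 47 percentage points lower from compound 1 to compound 3 (beyond the scatter). Among the compounds shown here, this is the only step in the set that changes one place alone, so it shows that the maximal response depends on the group at this carbon while the rest of the core stays the same. Compound 3 still reaches 40%, so a group with 0 hydrogen-bond donors at this place does not abolish the response.

The step does not separate the added methyl from the change of ring, and an unsubstituted 1H-imidazol-4-yl or an aminomethyl group on the same saturated carbon would pull these apart. Compound 2 differs from compound 3 in more than one place and gives no settled level for comparison: the several entries of compound 2 in this assay, 57%; 23% (2 entries)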